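The source may hold more compounds than are shown below. What is called first, only, known or untested is meant among the compounds shown, and "the series" means these compounds.

Series notes. Compound 1 `CCCC(=O)Nc1cccc(S(=O)(=O)Oc2ccccc2C(C)C)c1` in a functional assay on HT-29 cells (Homo sapiens) for antiproliferative activity, read by sulforhodamine B assay, with a stated time of 48 h (on this read-out higher numbers stand for weaker inhibition and lower numbers for stronger inhibition), gives 13000 nM, which places it second highest of the three numbers in hand. Compound 2 `CCCCCC(=O)Nc1cccc(S(=O)(=O)Oc2ccccc2C(C)C)c1` gives 19000 nM, the step being a 1.5-fold higher number from compound 1 to compound 2 (0.16 log units; within the scatter). Compound 3 `CC(C)c1ccccc1OS(=O)(=O)c1cccc(NC(=O)CCl)c1` gives 4500 nM; the steps to it are a 2.9-fold lower number from compound 1 to compound 3 (0.46 log units; beyond the scatter) and a 4.2-fold lower number from compound 2 to compound 3 (0.63 log units; beyond the scatter). Compound 4 `CC(C)c1ccccc1OS(=O)(=O)c1cccc(NC(=O)CCCl)c1` differs from compound 1 by chloro in place of methyl on a saturated chain carbon, two bonds along the chain from a carbonyl carbon. The two steps in which chloro enters on a saturated chain carbon bound to a carbonyl carbon bear on this, but here the chloro sits two bonds along the chain from the carbonyl carbon, so a smaller move in the same direction, or none beyond the scatter, is expected: a 1.6-fold lower number from compound 1 to compound 4 (0.21 log units; within the scatter). Compound 4 is therefore estimated at 8000 nM, within 3500 nM to 18000 nM.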

Compound 4, half-maximal inhibitory concentration: 11000 nM
For compound 4 the middle estimate is 1.4-fold (0.14 log units) below the measured one, within the range that was stated.
By their numbers in this assay, from the lowest: compound 3; then compounds 4, 1 and 2 (each within the scatter of the next).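

In this assay, chloro in place of methyl two bonds along the chain from the carbonyl carbon gives no change beyond the scatter (a 1.2-fold lower number from compound 1 to compound 4 (0.07 log units; within the scatter)), and the same holds against the longer chain (a 1.7-fold lower number from compound 2 to compound 4 (0.24 log units; within the scatter)). The lower number seen with chloro on a saturated chain carbon bound to a carbonyl carbon does not carry over to this place (a 2.4-fold higher number from compound 3 to compound 4 (0.39 log units; beyond the scatter)), so among these compounds the place of the chloro on the chain counts, not its presence alone. Nothing on hand accounts for this difference.

Still open, going by these compounds, is whether bromo or an amine on a saturated chain carbon bound to a carbonyl carbon would track compound 3 or compound 4. A longer chain ending in chloro is equally unresolved.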